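The compounds below may be only part of what the source reports. "The series", "measured", "known", "first", "only" and "open" are said of these compounds alone.

Series of triketone inhibitors of 4-hydroxyphenylpyruvate dioxygenase, measured in an assay for inhibition of 4-hydroxyphenylpyruvate dioxygenase (Sus scrofa); a lower number here means a stronger inhibitor, a higher number a weaker inhibitor. Compound 1 `Cc1ccccc1C(=O)C1C(=O)CCCC1=O` gives 3750 nM, the lowest of the three numbers shown. Compound 2 `O=C1CCCC(=O)C1C(=O)C1CC1` gives 6000 nM, within the scatter of compound 1. Among the measured compounds shown here, compound 3 `CC(=O)C1C(=O)CCCC1=O` gives 11200 nM, the only value beyond the scatter from compound 1. For the measured compounds named here, the one measured step, a 1.9-fold higher number from compound 2 to compound 3 (0.27 log units; within the scatter), sits on the carbonyl carbon and does not touch the aromatic ring, so it bears little on what follows. Compound 4 `O=C1CCCC(=O)C1C(=O)c1ccccc1I` differs from compound 1 as iodo in place of methyl on an aromatic carbon. Going by the values given here, no measured pair shows an aromatic substitution, so no direction can be drawn; a step of no more than the scatter is expected, a 1.1-fold lower number from compound 1 to compound 4 (0.03 log units; within the scatter). Compound 4 is therefore estimated at 3500 nM, with a range from 1200 nM to 10000 nM.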

Compound 4, half-maximal inhibitory concentration: 760 nM
The estimate for compound 4 lay 4.6-fold (0.66 log units) above the measured number, and the stated range ends above it.
By their numbers in this assay, from the lowest: compound 4; then compounds 1, 2 and 3 (each within the scatter of the next, the first and the last beyond it).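

In this assay, iodo in place of methyl on the aromatic carbon gives a 4.9-fold lower number from compound 1 to compound 4 (0.69 log units; beyond the scatter) for this step, the first in the series to lie beyond the scatter and the first on the aromatic ring. The number at this position therefore depends on the group it carries, even though the exchange leaves the heavy-atom count unchanged. Nothing measured here explains the step. Going by these compounds, whether chloro, methoxy or a carboxylic acid at this carbon would sit nearer to iodo or to methyl stays open. So does whether iodo on another aromatic carbon would give a similar step.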